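1-Benzothiophen-5-yl for 6-methylpyridin-3-yl: a clearance estimate

The compounds below may be only part of what the source reports. "The series", "measured", "known", "first", "only" and "open" are said of these compounds alone.

Measured so far in an ADME assay (liver) for metabolic stability, with Liver microsome (Rattus norvegicus) as the target, using microsomes and NADPH, with a stated time of 30 min, tested at 1 uM; on this read-out lower numbers stand for slow clearance and higher numbers for fast clearance:

compound 1 `Cn1cc(-c2cc(C(O)(C(F)(F)F)C(F)(F)F)cnc2N2CCN(S(=O)(=O)c3ccc(N)nc3)CC2)cn1`: 44 mL.min-1.g-1
compound 2 `CC(C)(C)n1cc(-c2cc(C(O)(C(F)(F)F)C(F)(F)F)cnc2N2CCN(S(=O)(=O)c3ccc(N)nc3)CC2)cn1`: 459 mL.min-1.g-1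
compound 3 `Cc1ccc(-c2cc(C(O)(C(F)(F)F)C(F)(F)F)cnc2N2CCN(S(=O)(=O)c3ccc(N)nc3)CC2)cn1`: 182 mL.min-1.g-1

Compound 3 holds the middle of these three numbers, as two measured steps show: a 4.1-fold higher number from compound 1 to compound 3 (0.62 log units; beyond the scatter), and a 2.5-fold lower number from compound 2 to compound 3 (0.40 log units; beyond the scatter). The next compound, compound 4 `Nc1ccc(S(=O)(=O)N2CCN(c3ncc(C(O)(C(F)(F)F)C(F)(F)F)cc3-c3ccc4sccc4c3)CC2)cn1`, carries 1-benzothiophen-5-yl in place of 6-methylpyridin-3-yl on an aromatic carbon. The two steps into compound 3 changed the group at this same place, and both lay beyond the scatter. A further step, a 10-fold higher number from compound 1 to compound 2 (1.02 log units; beyond the scatter), changed only the group on the aromatic nitrogen and was the largest of the three. None of these steps introduces 1-benzothiophen-5-yl, so they show only that this place can move the number appreciably, and they fix no direction for the new group. A modest rise is the tentative expectation, and the expected step is a 1.6-fold higher number from compound 3 to compound 4 (0.22 log units; within the scatter). For compound 4 the estimated value in this assay is 300 mL.min-1.g-1, with an expected range of 130 mL.min-1.g-1 to 650 mL.min-1.g-1.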

Compound 4, intrinsic clearance in microsomes: 487 mL.min-1.g-1
The estimate for compound 4 lay 1.6-fold (0.21 log units) below the measured number; the measured number falls inside the stated range.
By their numbers in this assay, from the lowest: compound 1; then compound 3; then compounds 2 and 4 (each within the scatter of the next).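

In this assay, 1-benzothiophen-5-yl, with its five-membered aromatic ring and six-membered aromatic ring of carbon only, gives a 2.7-fold higher number from compound 3 to compound 4 (0.43 log units; beyond the scatter) and so extends the range of groups that move the number at this place. With a 1.1-fold higher number from compound 2 to compound 4 (0.03 log units; within the scatter) as the printed step, 1-benzothiophen-5-yl cannot be told apart from 1-(tert-butyl)-1H-pyrazol-4-yl, so two quite different groups give the same clearance level here. The 1-methyl-1H-pyrazol-4-yl group of compound 1 remains the lowest of the four, and an 11-fold higher number from compound 1 to compound 4 (1.04 log units; beyond the scatter) is a step of about the same size as a 10-fold higher number from compound 1 to compound 2 (1.02 log units; beyond the scatter) at this read-out.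

Going by these compounds, whether an amine or a carboxylic acid on the 1-benzothiophen-5-yl group would bring the number back toward that of compound 1 stays open. Nothing measured in this set explains these differences.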